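Capping the carboxy group of compound 3

The compounds below may be only part of what the source reports. "The series", "measured", "known", "first", "only" and "open" are said of these compounds alone.

Measured so far in a physicochemical assay for solubility, read by spectrophotometry, in phosphate buffer, measured as kinetic solubility, with a stated time of 18 h, at pH 7.4 (on this read-out higher numbers stand for higher solubility and lower numbers for lower solubility), as follows:
- compound 1 `Cc1ccc(-c2nc3ccccc3s2)cc1NC(=O)c1cc([N+](=O)[O-])c(N2CCC(C(=O)O)CC2)cc1Cl` gives 590 nM
- compound 2 `O=C(Nc1nc2ccc(Cl)cc2s1)c1cc([N+](=O)[O-])ccc1Cl` gives 1200 nM
- compound 3 `COc1ccc(-c2nc3ccccc3s2)cc1NC(=O)c1cc([N+](=O)[O-])c(N2CCC(C(=O)O)CC2)cc1Cl` gives 210 nM

Compound 3 has the lowest number of the three, and both other compounds lie beyond the scatter from it. The next compound is compound 4 `COC(=O)C1CCN(c2cc(Cl)c(C(=O)Nc3cc(-c4nc5ccccc5s4)ccc3OC)cc2[N+](=O)[O-])CC1` which differs from compound 3 by one change methyl in place of hydrogen on an oxygen next to a carbonyl group and this reads as carboxy to methoxycarbonyl.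

Going by the values given here, no measured step covers this change. Among the compounds with values here, the only single-change step is a 2.8-fold lower number from compound 1 to compound 3 (0.45 log units; beyond the scatter) with methoxy in place of methyl on an aromatic carbon. It does not touch the carboxy group and serves only as a guide to size. Within the data shown here, compound 2 has no 4-carboxypiperidin-1-yl group and gives 1200 nM but it differs from compound 3 in more than this one place, so it fixes no step. It does caution against assuming that a number must fall once the carboxy group is gone.

A modest move to a lower number is still expected in this assay although the direction is a judgement and not a measured result. Among the measured compounds shown here, the expected change is a 1.9-fold lower number from compound 3 to compound 4 (0.28 log units; within the scatter) and its size is similar to the one guiding step. For compound 4 the estimate is 110 nM with an expected range from 35 nM to 350 nM as its span.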

Compound 4, solubility: 170 nM
Beside the measured number, compound 4's estimate is 1.5-fold (0.19 log units) below it; the range from low to high includes it.
By their numbers in this assay, from the lowest: compounds 4 and 3 (each within the scatter of the next); then compound 1; then compound 2.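

In this assay, going by these compounds alone, the first single-change step at this position, carboxy to methoxycarbonyl within the 4-carboxypiperidin-1-yl group, reads as a 1.2-fold lower number from compound 3 to compound 4 (0.09 log units; within the scatter) and so does not separate the two compounds. Within the data shown here, the only earlier step, a 2.8-fold lower number from compound 1 to compound 3 (0.45 log units; beyond the scatter), lay beyond the scatter but changed a different place on the molecule and said nothing about the carboxy group. Here, on the shared core with its methoxy group, methyl in place of hydrogen on this oxygen gives no readable difference, and no measurement bearing on the reason for this result is available.

Only hydrogen and methyl on this oxygen are shown, so it remains open whether a longer chain on the oxygen, a primary amide, or an amine in place of the carboxy group would give a step beyond the scatter. From the compounds shown here alone, it is also open whether the same change gives a similar step on the core of compound 1 , which carries methyl where compound 3 carries methoxy.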